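Cyano in place of tert-butyl in compound 3

The compounds below may be only part of what the source reports. "The series", "measured", "known", "first", "only" and "open" are said of these compounds alone.

Compound 1 `COc1ccc(/C=C2\CN(C)C/C(=C\c3ccccc3F)C2=O)cc1OC`: 8760 nM
Compound 2 `COc1cc(/C=C2\CN(C)C/C(=C\c3ccccc3F)C2=O)cc(OC)c1OC`: 670 nM
Compound 3 `CN1C/C(=C\c2ccc(C(C)(C)C)cc2)C(=O)/C(=C/c2ccccc2F)C1`: 9120 nM

In a functional assay on HepG2 cells (Homo sapiens) for cytotoxicity, read by MTT assay, with a stated time of 24 h (on this read-out higher numbers stand for weaker inhibition and lower numbers for stronger inhibition), compound 3 gives 9120 nM, level with compound 1 at 8760 nM, while compound 2 gives 670 nM, a much lower number than either. Compound 4 `CN1C/C(=C\c2ccc(C#N)cc2)C(=O)/C(=C/c2ccccc2F)C1` carries cyano in place of tert-butyl on an aromatic carbon, para to a large group (cyano in place of tert-butyl on an aromatic carbon). Going by the values given here, the only measured step, a 13-fold lower number from compound 1 to compound 2 (1.12 log units; beyond the scatter), is large, but it comes from methoxy in place of hydrogen, a different change. It therefore sets no direction for cyano, and no step beyond the scatter is expected. The estimated step is a 1.7-fold lower number from compound 3 to compound 4 (0.22 log units; within the scatter). For compound 4 the expected value is 5500 nM, with an estimated range of 1500 nM to 18000 nM.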

Compound 4, half-maximal inhibitory concentration: 590 nM
The estimate for compound 4 lay 9.3-fold (0.97 log units) above the measured number, and the stated range ends above it.
By their numbers in this assay, from the lowest: compounds 4 and 2 (each within the scatter of the next); then compounds 1 and 3 (each within the scatter of the next).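

In this assay, cyano in place of tert-butyl gives a 15-fold lower number from compound 3 to compound 4 (1.19 log units; beyond the scatter), so the group on this aromatic carbon, para to a large group, strongly affects the read-out. Going by these compounds alone, the earlier compounds showed a large step only for methoxy in place of hydrogen, and this is the first for a replacement of one group by another. Nothing given here accounts for the step.

On these data alone, whether it reflects the arrival of cyano or the loss of tert-butyl stays open. So does whether an amine or a carboxylic acid on this carbon would give a number close to that of compound 4.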